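The source may report more compounds than this note shows. Statements on the series, on what has been measured and on what is new or still open speak of the compounds shown alone.

Of the compounds shown here, three have been measured in an assay on HEK293 cells for positive allosteric modulation of metabotropic glutamate receptor 2 (Rattus norvegicus), read by thallium flux, with a stated time of 2.5 min; a higher number here means that more compound is needed for the effect, a lower number that less compound is needed. Compound 1, with the structure `Cc1cc(C(=O)O)ccc1OCCCCOc1ccc(C(=O)CC(C)C)c(O)c1C`, gives 192 nM. Compound 2, with the structure `Cc1c(OCCCCOc2ccccc2C(=O)O)ccc(C(=O)CC2CCCC2)c1O`, gives 335 nM. Compound 3, with the structure `Cc1c(OCCCCOc2ccccc2C(=O)O)ccc(C(=O)CC(C)C)c1C`, gives 976 nM, the highest of the three numbers; the gaps to compound 2 and to compound 1 both lie beyond the usual scatter, so compound 3 needs clearly more material than either of the other two.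

The next compound, compound 4, has the structure `Cc1c(OCCCCOc2ccccc2C(=O)O)ccc(C(=O)CC(C)C)c1O`. It differs from compound 3 in a single place: hydroxy in place of methyl on an aromatic carbon. Compound 1 and compound 2 both carry a hydroxy group on the shared core, and both show lower numbers than compound 3, which lacks one. On that basis the step in this assay from compound 3 to compound 4 is expected to be a drop of the same order as the gaps already seen, namely a 3.9-fold lower number from compound 3 to compound 4 (0.59 log units; beyond the scatter), rather than a change within the scatter. Compound 4 is therefore estimated at 250 nM in this assay, with a likely range from 100 nM to 600 nM.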

Compound 4, half-maximal effective concentration: 415 nM
Beside the measured number, compound 4's estimate is 1.7-fold (0.22 log units) below it; measured number inside the range.
By their numbers in this assay, from the lowest: compounds 1, 2 and 4 (each within the scatter of the next, the first and the last beyond it); then compound 3.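

Hydroxy in place of methyl on this aromatic carbon, ortho to a methyl group and ortho to an isobutylcarbonyl group, gives a 2.4-fold lower number from compound 3 to compound 4 (0.37 log units; beyond the scatter) in this assay, a modest step beyond the scatter and the first reading of this change on its own, since the earlier compounds differed from one another in more than one place. Among these compounds, with the hydroxy group in place, isopropyl in place of cyclopentyl gives a 1.2-fold higher number from compound 2 to compound 4 (0.09 log units; within the scatter), which lies within the scatter, whereas 2-carboxyphenyl in place of 4-carboxy-2-methylphenyl gives a 2.2-fold higher number from compound 1 to compound 4 (0.33 log units; beyond the scatter), a modest step beyond it, so this position is not the only one where a single change shifts the number. Nothing measured here explains why the number shifts at this carbon.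

From the compounds shown here alone, how a methoxy group or an amine on this carbon would read remains open. Also open, going by these compounds, is whether hydroxy in place of methyl gives a step of similar size in compounds carrying cyclopentyl or 4-carboxy-2-methylphenyl, as this change has been read only in the pair with isopropyl and 2-carboxyphenyl.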